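Aryl exchange on the methylated amide of compound 3

The source may hold more compounds than are shown below. What is called first, only, known or untested is meant among the compounds shown, and "the series" means these compounds.

In a functional assay on MDA-MB-231 cells (Homo sapiens), read by microscopy and transwell migration, with a stated time of 24 h (a higher number here means a weaker inhibitor, a lower number a stronger inhibitor), compound 1 (`O=C(Nc1nc(-c2ccccc2Cl)cs1)c1ccccc1`) gives 15000 nM and compound 2 (`O=C(Nc1nc(-c2cccc(Br)c2)cs1)c1ccccc1`) gives 10000 nM. Compound 3 (`CN(C(=O)c1ccccc1)c1nc(-c2ccccc2Cl)cs1`) gives 41.6 nM, the lowest number of the three. Compound 4 (`CN(C(=O)c1ccccc1)c1nc(-c2cccc(Br)c2)cs1`) differs from compound 3 in one place: 3-bromophenyl in place of 2-chlorophenyl on an aromatic carbon, with 3-bromophenyl in place of 2-chlorophenyl on an aromatic carbon. The same exchange with the amide hydrogen in place gave a 1.5-fold lower number from compound 1 to compound 2 (0.18 log units; within the scatter), within the scatter. Methyl in place of that hydrogen gave a 360-fold lower number from compound 1 to compound 3 (2.56 log units; beyond the scatter), a large step, so the exchange may not carry over unchanged. No step beyond the scatter is expected in this assay. The expected step is a 1.0-fold lower number from compound 3 to compound 4 (0.02 log units; within the scatter). Compound 4 is estimated at 40 nM, with an expected range of 10 nM to 250 nM.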

Compound 4, half-maximal inhibitory concentration: 437 nM
The estimate for compound 4 lay 11-fold (1.04 log units) below the measured number; measured number above the stated range.
By their numbers in this assay, from the lowest: compound 3; then compound 4; then compounds 2 and 1 (each within the scatter of the next).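

In this assay, the aryl exchange that made no difference beyond the scatter with the amide hydrogen present matters on the methylated amide, giving an 11-fold higher number from compound 3 to compound 4 (1.02 log units; beyond the scatter). The two changes therefore do not add independently: the same change on two cores in this assay, a 1.5-fold lower number (0.18 log units; within the scatter) from compound 1 to compound 2 and an 11-fold higher number (1.02 log units; beyond the scatter) from compound 3 to compound 4, 16-fold (1.20 log units) apart, beyond the scatter of two such steps. Methyl on the amide nitrogen still lowers the number with 3-bromophenyl in place, giving a 23-fold lower number from compound 2 to compound 4 (1.36 log units; beyond the scatter), but the size of this step depends on the aryl group: the same change on two cores in this assay, a 360-fold lower number (2.56 log units; beyond the scatter) from compound 1 to compound 3 and a 23-fold lower number (1.36 log units; beyond the scatter) from compound 2 to compound 4, 16-fold (1.20 log units) apart, beyond the scatter of two such steps.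

Open, going by these compounds, is whether the gap on the methylated amide follows the halogen or its place on the phenyl, which 2-bromophenyl and 3-chlorophenyl would separate. Also open, on these data alone, is whether ethyl in place of methyl on the amide nitrogen keeps the lower numbers.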